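The compounds below may be only part of what the source reports. "The series", "measured", "known", "first", "only" and "open" are said of these compounds alone.

Of the compounds shown here, two have so far been measured in an ADME assay for permeability, using PAMPA; a lower number here means that the compound crosses the layer more slowly, a higher number that the compound crosses the layer faster. Compound 1 `O=C(/C=N/O)NCCN1CCCC1` gives 1.1 10^-6 cm/s in this assay. Compound 2 `NCCNC(=O)/C=N/O` gives 1.4 10^-6 cm/s in this assay. The gap between these two numbers is of the size that repeated measurements of this kind show anyway, so neither compound can be called the faster of the pair; on the numbers shown, compound 2 simply sits alongside compound 1.

Compound 3 `C[N+](C)(C)CCNC(=O)/C=N/O` has not yet been measured. It differs from compound 2 in one place: a group of 4 heavy atoms (3 carbon, 1 nitrogen; no ring) in place of one nitrogen atom, on a saturated chain carbon, two bonds along the chain from an amide-type nitrogen. Among the measured compounds shown here, no measured pair of compounds shows a step of this kind, so nothing in the data fixes how large its effect is. A downward step is nevertheless expected, of a size beyond the scatter, and compound 3 is estimated to come in at 0.3 10^-6 cm/s in this assay, somewhere between 0.05 10^-6 cm/s and 1 10^-6 cm/s. That estimate means an expected step from compound 2 to compound 3 of a 4.7-fold lower number from compound 2 to compound 3 (0.67 log units; beyond the scatter), an expectation rather than a measurement, since compound 2 at 1.4 10^-6 cm/s is the only anchor it rests on.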

Compound 3, apparent permeability: 1.6 10^-6 cm/s
Compound 3: middle estimate off by 5.3-fold (0.73 log units), on the low side, outside the stated range (above it).
By their numbers in this assay, from the lowest: compounds 1, 2 and 3 (each within the scatter of the next).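

In this assay, putting a group of 4 heavy atoms (3 carbon, 1 nitrogen; no ring) with a net charge of +1 in place of the amino group, on a saturated chain carbon, two bonds along the chain from an amide-type nitrogen, gives a 1.1-fold higher number from compound 2 to compound 3 (0.06 log units; within the scatter) in this read-out. Among the compounds shown here, this is the first comparison in the set that isolates a change in one place, and it shows that this exchange, which removes the hydrogen-bond donor and acceptor counted for the amino group and adds a net charge, leaves the two compounds indistinguishable in this assay. For the compounds shown here, nothing measured so far explains why the two compounds stand so close together.

This single step cannot say whether other groups at the same place would also stay within the scatter, for instance a dimethylamino group, a carboxylic acid or a longer chain ending in an amine. Going by these compounds alone, it also leaves open whether the same exchange would give a similar result on a different core, since only one such pair is available here.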